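This account rests on a few compounds, and the source may have more. Where it says the series, first, only, none or still open, it means among the compounds named here.

Of the compounds shown here, three sharing one core have been measured in a functional assay on A549 cells (Homo sapiens) for inhibition, read by MTT assay, with a stated time of 72 h; on this read-out lower numbers stand for stronger inhibition and higher numbers for weaker inhibition: compound 1 `CC(C)(C)n1cc2c(n1)C(=O)CC1(CCN(C(=O)c3cc(-c4ccc(Cl)cc4)nc4ccccc34)CC1)O2` gives 2330 nM, compound 2 `CC(C)(C)n1cc2c(n1)C(=O)CC1(CCN(C(=O)c3cc(-c4ccc(F)cc4)nc4ccccc34)CC1)O2` gives 5770 nM, and compound 3 `CC(C)(C)n1cc2c(n1)C(=O)CC1(CCN(C(=O)c3cc(-c4ccc(N)cc4)nc4ccccc34)CC1)O2` gives 970 nM. Compound 3 has the lowest number of the three, and its steps to the other two lie beyond the scatter. The next compound, compound 4 `CC(C)(C)n1cc2c(n1)C(=O)CC1(CCN(C(=O)c3cc(N4CCNCC4)nc4ccccc34)CC1)O2`, carries piperazin-1-yl in place of 4-aminophenyl on an aromatic carbon, next to the ring nitrogen (piperazin-1-yl in place of 4-aminophenyl on an aromatic carbon).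

The measured steps bear on this change only indirectly. Each one swaps a single group on the aromatic ring that compound 4 no longer has: a 2.5-fold higher number from compound 1 to compound 2 (0.39 log units; beyond the scatter), a 2.4-fold lower number from compound 1 to compound 3 (0.38 log units; beyond the scatter) and a 5.9-fold lower number from compound 2 to compound 3 (0.77 log units; beyond the scatter). Within the data shown here, all three are modest, but none replaces the whole ring, so the data offer no direct precedent and the uncertainty is wide. With compound 3 already lowest at 970 nM, a modest move towards a higher number in this assay seems the likelier outcome, though a lower number cannot be ruled out. The expected change is a 3.1-fold higher number from compound 3 to compound 4 (0.49 log units; beyond the scatter). The estimated value for compound 4 is 3000 nM, with an expected range from 700 nM to 12000 nM.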

Compound 4, half-maximal inhibitory concentration: > 10000 nM
Compound 4: no number, only a limit; the forecaster's own chance of this, stated with the estimate: 10%; middle value at least 3.3-fold (0.52 log units) away from the limit.
By their numbers in this assay, from the lowest: compound 3; then compound 1; then compound 2. At a limit, above all of these: compound 4.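

In this assay, compound 4 gives a limit rather than a number: the limit of > 10000 nM in this assay, at which 1 of the 4 values shown sits. Putting piperazin-1-yl in place of 4-aminophenyl gives an at least 10-fold higher number from compound 3 to compound 4 (1.01 log units; beyond the scatter), a large step, whereas swapping a single group on the aromatic ring gave only modest steps, the biggest being a 5.9-fold lower number from compound 2 to compound 3 (0.77 log units; beyond the scatter). Against the 4-chlorophenyl group the change gives an at least 4.2-fold higher number from compound 1 to compound 4 (0.63 log units; beyond the scatter), and against the 4-fluorophenyl group it gives an at least 1.7-fold higher number from compound 2 to compound 4 (0.23 log units; that floor lies within the scatter), so the last of these steps does not firmly settle an order, although the result still sets the non-aromatic ring apart as the only group here without a measured number.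

As far as these compounds go, how much weaker this ring truly is remains open, since only a limit is available for it. It is also unclear whether the loss comes from removing the aromatic ring or from bringing in the second ring nitrogen: a morpholin-4-yl group would keep a non-aromatic ring with a different second hetero atom, and a pyridin-4-yl ring would keep an aromatic ring that contains nitrogen.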